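The compounds below may be only part of what the source reports. "The series", "measured", "known", "first", "only" and "open" are said of these compounds alone.

Measured so far:
- compound 1 `CSc1ccc(C)cc1NCC1=NCCN1`: 17.4 nM
- compound 2 `COc1ccc(SC)c(NCC2=NCCN2)c1`: 107 nM
- compound 3 `CSc1ccc(Cl)cc1NCC1=NCCN1`: 4.68 nM

In an assay for binding affinity to Alpha-1D adrenergic receptor (Homo sapiens), read by radioligand binding (on this read-out higher numbers stand for weaker inhibition and lower numbers for stronger inhibition), compound 3 gives the lowest number of the three: there was a 3.7-fold lower number from compound 1 to compound 3 (0.57 log units; beyond the scatter) and a 23-fold lower number from compound 2 to compound 3 (1.36 log units; beyond the scatter). Compound 4 `CSc1ccc(C(F)(F)F)cc1NCC1=NCCN1` differs from compound 3 by trifluoromethyl in place of chloro on an aromatic carbon. Among the measured compounds shown here, no measured step exchanges chloro for trifluoromethyl, so the closest guidance comes from the steps at the same aromatic carbon: a 3.7-fold lower number from compound 1 to compound 3 (0.57 log units; beyond the scatter) and a 6.1-fold higher number from compound 1 to compound 2 (0.79 log units; beyond the scatter), one modest and one modest in the other direction. These show that this carbon tolerates change without any one group being decisive, and the outcome for trifluoromethyl is not fixed by the data. Compound 4 is therefore estimated at 8 nM (range 2.5 nM to 30 nM), which means an expected 1.7-fold higher number from compound 3 to compound 4 (0.23 log units; within the scatter).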

Compound 4, inhibition constant: 479 nM
Estimate against measurement, compound 4: 60-fold (1.78 log units) below, outside the stated range (above it).
By their numbers in this assay, from the lowest: compound 3; then compound 1; then compound 2; then compound 4.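

In this assay, among the compounds shown here, this carbon proves far less forgiving than the earlier compounds suggested: there is a 100-fold higher number from compound 3 to compound 4 (2.01 log units; beyond the scatter) on exchanging chloro for trifluoromethyl, together with a 28-fold higher number from compound 1 to compound 4 (1.44 log units; beyond the scatter) and a 4.5-fold higher number from compound 2 to compound 4 (0.65 log units; beyond the scatter) when methyl and methoxy are the groups replaced. Chloro and trifluoromethyl therefore cannot be treated as interchangeable here, and compound 4 now has the highest number of the four. Nothing available explains this loss of binding.
The compounds shown leave open how fluoro, bromo, a nitrile or an amine would fare at this carbon, and whether any of them would match chloro.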